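A few compounds are considered here, and "the series" means these few. Any claim that something is new, unique, unknown or untested is made for them only; others in the source may bear on it.

Compound 1, `COc1ccc(-c2c(CNC(C)(C)C)c(C(=O)O)nn2-c2ccccc2)cc1`: in a functional assay on HT-29 cells (Homo sapiens) for inhibition, read by sulforhodamine B assay, with a stated time of 48 h (a lower number here means a stronger inhibitor of growth, a higher number a weaker inhibitor of growth), compound 1 gives only a limit, > 659000 nM.
Compound 2, `CC(C)(C)NCc1c(C(=O)O)nn(-c2ccccc2)c1-c1ccc([N+](=O)[O-])cc1`: in this assay compound 2 gives only a limit, > 634000 nM.
Compound 3, `COc1ccc(-c2c(CNC(C)(C)C)c(C(=O)O)nn2-c2ccc(Cl)cc2)cc1`: in this assay compound 3 gives only a limit, > 605000 nM.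

None of these three values is a number; each is a limit of the assay, so none of the three compounds inhibited growth within the range that was tested. Compound 2 differs from compound 1 by nitro in place of methoxy on an aromatic carbon. The step that the two limits leave unreadable from compound 1 to compound 2 is unreadable because the limit of > 659000 nM in this assay, at which 1 of the 3 values shown sits, and the limit of > 634000 nM in this assay, at which 1 of the 3 values shown sits, hold both values. Compound 3 differs from compound 1 by chloro in place of hydrogen on an aromatic carbon, which is the only difference between the two cores. The step that the two limits leave unreadable from compound 1 to compound 3 is likewise unreadable because the limit of > 659000 nM in this assay, at which 1 of the 3 values shown sits, and the limit of > 605000 nM in this assay, at which 1 of the 3 values shown sits, hold both values.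

Compound 4, `CC(C)(C)NCc1c(C(=O)O)nn(-c2ccc(Cl)cc2)c1-c1ccc([N+](=O)[O-])cc1`, has not yet been measured. It differs from compound 3 by nitro in place of methoxy on an aromatic carbon, the same change that takes compound 1 to compound 2, at the same place. Beside the unreadable a step that the two limits leave unreadable from compound 1 to compound 2, the step from compound 3 to compound 4 in this assay is expected to be a step that the limit leaves unreadable from compound 3 to compound 4. That expectation rests on compound 3 showing only the limit > 605000 nM. Compound 4 is therefore estimated to give about 700000 nM in this assay, most likely again only as a limit.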

Compound 4, concentration for 50% growth inhibition: > 583000 nM
Compound 4 ended at the assay's limit (the forecaster's own chance of this, stated with the estimate: 85%); the middle value lies beyond the limit too.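

In this assay compound 4 gives > 583000 nM, which is again a limit and not a number. The steps from compound 3 to compound 4 and from compound 2 to compound 4 therefore cannot be read. The compounds shown leave open whether nitro in place of methoxy, or chloro in place of hydrogen, changes growth inhibition at all.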